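The compounds below may be only part of what the source reports. "The series", "measured", "known", "first", "only" and "open" are said of these compounds alone.

Measured so far:
Compound 1 `COc1cccc(NC(=S)NC2CC(C)(C)Oc3ccc(Br)cc32)c1` gives 87000 nM in a functional assay on T98G cells (Homo sapiens) for inhibition, read by MTT assay, with a stated time of 72 h; a higher number here means a weaker inhibitor, a lower number a stronger inhibitor.
Compound 2 `CC1(C)CC(NC(=O)NCc2ccccc2)c2cc(Cl)ccc2O1` gives 15000 nM in this assay.
Compound 3 `CCOC(=O)NC1CC(C)(C)Oc2ccc(Cl)cc21` gives "not determined" (no result reported) in this assay.

Of the two compounds with a number, compound 1 stands at the higher one, and the gap to compound 2 lies beyond the usual scatter. Compound 4 `CC1(C)CC(NC(=S)Nc2ccc(Cl)cc2)c2cc(Br)ccc2O1` differs from compound 1 in one place: 4-chlorophenyl in place of 3-methoxyphenyl on an amide-type nitrogen. Among the compounds with values here, no pair of measured compounds shows what this swap does on its own; compound 2 differs from both in more than one place and offers no such comparison. With nothing pointing in either direction, a change no larger than the scatter is expected. For compound 4 the estimate is 60000 nM, within 20000 nM to 200000 nM, meaning an expected step of a 1.5-fold lower number from compound 1 to compound 4 (0.16 log units; within the scatter).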

Compound 4, half-maximal inhibitory concentration: 22000 nM
The estimate for compound 4 lay 2.7-fold (0.44 log units) above the measured number; the measured number falls inside the stated range.
By their numbers in this assay, from the lowest: compounds 2 and 4 (each within the scatter of the next); then compound 1.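

Putting 4-chlorophenyl in place of 3-methoxyphenyl on this amide-type nitrogen, next to the thiocarbonyl carbon, gives a 4.0-fold lower number from compound 1 to compound 4 (0.60 log units; beyond the scatter) in this assay. Within the data shown here, this is the first comparison here that differs in one place only, and it shows that the group on this nitrogen can shift the number beyond the usual scatter, though modestly. No measurement at hand says why the number moved.

The compounds shown do not separate the effect of adding chlorine from that of losing methoxy. As far as these compounds go, how an amine or a carboxylic acid on this phenyl ring would behave also remains open.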